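Second methyl on the chain carbon bearing the ether oxygen

The source may hold more compounds than are shown below. What is called first, only, known or untested is meant among the compounds shown, and "the series" means these compounds.

Working notes on the series. Compound 1 `COc1ccc2nc(C)cc(OCC(=O)Nc3cc(C)cc(C)c3)c2c1` gives 20000 nM in a toxicity assay on HepG2 cells (Homo sapiens) for inhibition, read by CellTiter-Glo, with a stated time of 48 h; on this read-out lower numbers stand for stronger inhibition and higher numbers for weaker inhibition. Compound 2 `CCCc1cc(OCC(=O)Nc2cc(C)cc(C)c2)c2cc(OC)ccc2n1` gives 12600 nM, and compound 3 `COc1ccc2nc(C)cc(OC(C)C(=O)Nc3cc(C)cc(C)c3)c2c1` gives 39800 nM, the highest number of the three; the step of a 2.0-fold higher number from compound 1 to compound 3 (0.30 log units; within the scatter) stays inside the scatter, whereas the gap between compound 3 and compound 2 lies beyond it. Compound 4 `COc1ccc2nc(C)cc(OC(C)(C)C(=O)Nc3cc(C)cc(C)c3)c2c1` is not yet measured and differs from compound 3 by methyl in place of hydrogen on a saturated chain carbon bound to a carbonyl carbon, an oxygen on an aromatic ring and a saturated chain carbon. For the measured compounds named here, the only measured step that bears on this change is the earlier addition of a methyl at the same chain carbon, a 2.0-fold higher number from compound 1 to compound 3 (0.30 log units; within the scatter), which did not leave the scatter. The step of a 1.6-fold lower number from compound 1 to compound 2 (0.20 log units; within the scatter) concerns a different site and also stayed inside the scatter. A second methyl at the same carbon is therefore expected to move the number little, if at all, with any drift toward a higher number. Compound 4 is estimated at 50000 nM, with a range of 20000 nM to 130000 nM. The expected step of a 1.3-fold higher number from compound 3 to compound 4 (0.10 log units; within the scatter) is thus within the scatter.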

Compound 4, half-maximal inhibitory concentration: > 100000 nM
Compound 4 gave a limit, no number (the forecaster's own chance of this, stated with the estimate: 35%); middle value at least 2.0-fold (0.30 log units) away from the limit.
By their numbers in this assay, from the lowest: compounds 2, 1 and 3 (each within the scatter of the next, the first and the last beyond it). At a limit, above all of these: compound 4.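

For the compounds shown here, at the saturated chain carbon bound to a carbonyl carbon and an oxygen on an aromatic ring, the first methyl gave a 2.0-fold higher number from compound 1 to compound 3 (0.30 log units; within the scatter), whereas the second gave an at least 2.5-fold higher number from compound 3 to compound 4 (0.40 log units; beyond the scatter), the first change at this position to leave the scatter in this assay. Compound 4 stands at > 100000 nM, which is a limit of the assay and not a number. The full size of the second step therefore stays unread, and only its lower bound can be set against the first step: the limit of > 100000 nM in this assay, at which 1 of the 4 values shown sits.

The compounds shown leave open whether a longer chain such as ethyl at this carbon, or a cyclopropane ring built on it, would behave like the two methyl groups. They also leave open how an amine or a carboxylic acid at this carbon would read in this assay.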